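The compounds below may be only part of what the source reports. "The series", "measured", "known", "first", "only" and "open" are said of these compounds alone.

Measured so far:
compound 1 `Cc1cc(=O)n(-c2ccc(Br)cc2F)nc1C(=O)Nc1ccc(Oc2ncnc3ccsc23)cc1`, 7930 nM
compound 2 `Cc1ccc(-n2nc(C(=O)Nc3ccc(Oc4ncnc5ccsc45)cc3)c(C)cc2=O)cc1`, 11500 nM

Both were run in a functional assay on A549 cells (Homo sapiens) for cytotoxicity, read by MTT assay, with a stated time of 72 h; on this read-out lower numbers stand for stronger inhibition and higher numbers for weaker inhibition. Among the measured compounds shown here, compound 2 gives the higher of the two numbers, but the only measured step, a 1.5-fold higher number from compound 1 to compound 2 (0.16 log units; within the scatter), is within the scatter, so the two compounds cannot be ordered on this read-out.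

Compound 3 `Cc1cc(=O)n(-c2ccc(F)cc2)nc1C(=O)Nc1ccc(Oc2ncnc3ccsc23)cc1` is not yet measured. Relative to compound 2 it carries fluoro in place of methyl on an aromatic carbon. For the measured compounds named here, the one measured step concerns the same ring on the aromatic nitrogen, a 1.5-fold higher number from compound 1 to compound 2 (0.16 log units; within the scatter), and it was within the scatter; there the whole halogenated ring was traded for the methyl-bearing ring. Going by the values given here, no measured pair isolates a methyl-to-fluoro exchange, so no step beyond the scatter is expected, and the estimated step is a 1.2-fold lower number from compound 2 to compound 3 (0.08 log units; within the scatter). Compound 3 is therefore expected to give 9500 nM, with a range from 4000 nM to 22000 nM.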

Compound 3, half-maximal inhibitory concentration: 2360 nM
Compound 3: middle estimate off by 4.0-fold (0.60 log units), on the high side; measured number below the stated range.
By their numbers in this assay, from the lowest: compound 3; then compounds 1 and 2 (each within the scatter of the next).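

In this assay, the ring on the aromatic nitrogen now gives steps beyond the scatter: 4-fluorophenyl in place of 4-methylphenyl gives a 4.9-fold lower number from compound 2 to compound 3 (0.69 log units; beyond the scatter), and 4-fluorophenyl in place of 4-bromo-2-fluorophenyl gives a 3.4-fold lower number from compound 1 to compound 3 (0.53 log units; beyond the scatter). Compounds 1 and 2 could not be ordered, so the earlier pair gave no sign that this ring affects the read-out, whereas compound 3 now stands lowest of the three, with both of its steps beyond the scatter. Nothing available explains the lower number of compound 3.

Going by these compounds, compound 1 differs from compound 3 by the bromo and the second fluoro together, so their separate contributions remain open. A plain phenyl, 4-chlorophenyl or 4-methoxyphenyl ring would test whether the step is specific to fluoro at this place.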